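The source may hold more compounds than are shown below. What is called first, only, known or untested is meant among the compounds shown, and "the series" means these compounds.

Measured compounds:
- compound 1, `CCCCCCCc1cn(C(c2ccccc2)c2cc3cc(Br)ccc3nc2OC)nn1`: 4.42%
- compound 2, `CCCc1cn(C(c2ccccc2)c2cc3cc(Br)ccc3nc2OC)nn1`: 8.3%
- compound 3, `COc1nc2ccc(Br)cc2cc1C(c1ccccc1)n1cc(CO)nn1`: 4.65%

In an ADME assay on PC-3 cells (Homo sapiens) for cytotoxicity, read by sulforhodamine B assay, with a stated time of 48 h, tested at 10 uM (on this read-out lower numbers stand for less inhibition and higher numbers for more inhibition at the one concentration tested (going by the name of the read-out)), compound 3 gives 4.65%, the second highest of the three numbers, yet the steps of a number 0.2 percentage points higher from compound 1 to compound 3 (within the scatter) and a number 3.7 percentage points lower from compound 2 to compound 3 (within the scatter) both lie within the scatter, so the three compounds are indistinguishable here. Compound 4 is `COc1nc2ccc(Br)cc2cc1C(c1ccccc1)n1cc(-c2cccc(F)c2)nn1`; it differs from compound 3 in one place: 3-fluorophenyl in place of hydroxymethyl on an aromatic carbon. The measured steps that touch this same aromatic carbon of the five-membered ring are a number 0.2 percentage points higher from compound 1 to compound 3 (within the scatter) and a number 3.7 percentage points lower from compound 2 to compound 3 (within the scatter), and also a number 3.9 percentage points higher from compound 1 to compound 2 (within the scatter); every one of them stays within the scatter. For the measured compounds named here, no measured step brings in an aromatic ring at this place. The step of a number 2.4 percentage points higher from compound 3 to compound 4 (within the scatter) is therefore expected to stay within the scatter. Compound 4 is estimated at 7%, in the range -3% to 18%.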

Compound 4, a percentage reported as inhibition, at one concentration (the size of the read-out at that concentration, not a potency): 14.6%
Estimate against measurement, compound 4: 7.6 percentage points below, and the stated range covers the measured number.
By their numbers in this assay, from the lowest: compounds 1, 3, 2 and 4 (each within the scatter of the next, the first and the last beyond it).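

Of the changes at this carbon, only the move from heptyl to 3-fluorophenyl gives a step that clears the usual scatter in this assay (a number 10.2 percentage points higher from compound 1 to compound 4 (beyond the scatter)), and only modestly. The steps from the two smaller groups stay inside it (a number 10 percentage points higher from compound 3 to compound 4 (within the scatter)) (a number 6.3 percentage points higher from compound 2 to compound 4 (within the scatter)), so 3-fluorophenyl is not separated from hydroxymethyl or propyl. Nothing measured here accounts for the step from heptyl. From the compounds shown here alone, whether a pyridine ring, an amine or a carboxylic acid at this carbon would stand clearly apart from these groups remains open.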